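This account rests on a few compounds, and the source may have more. Where it says the series, first, only, none or still open, it means among the compounds named here.

In an assay on CHO cells for displacement of a labelled ligand from adenosine receptor A1 (Homo sapiens), read by scintillation counting, with a stated time of 1 h, tested at 1 uM (a lower number here means less inhibition, a higher number more inhibition at the concentration tested (going by the name of the read-out)), compound 1 `Nc1ncc(-c2cccc(Cl)c2)c(-c2ccccc2)n1` gives > 80%, which is a limit of the assay and not a number (the limit of > 80% in this assay, at which 1 of the 3 values shown sits). Compound 2 `COc1cc(-c2cnc(N)nc2-c2ccccc2)cc(OC)c1OC` gives 56%, and compound 3 `Nc1ncc(-c2ccc(OCc3ccccc3)c(Cl)c2)c(-c2ccccc2)n1` gives 38%. Putting benzyloxy in place of hydrogen on an aromatic carbon brought a number at least 42 percentage points lower from compound 1 to compound 3 (beyond the scatter), a large fall in inhibition.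

Compound 4 `Clc1cccc(-c2cnc(NCc3ccccc3)nc2-c2ccccc2)c1` has not yet been measured. It differs from compound 1 by benzyl in place of hydrogen on a nitrogen on an aromatic ring; the same difference, cut one bond further out, reads amino to benzylamino. For the measured compounds named here, the only measured step that bears on this change is the one from compound 1 to compound 3, where a group carrying a benzyl ring also entered, though on an aromatic carbon rather than on a nitrogen, and inhibition dropped by a large amount. A downward step beyond the scatter is therefore expected here as well. Compound 4 is estimated at 40%, within a range of 10% to 75%. That estimate for compound 4 corresponds to an expected step of a number at least 40 percentage points lower from compound 1 to compound 4 (beyond the scatter).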

Compound 4, a percentage reported as inhibition, at one concentration (the size of the read-out at that concentration, not a potency): 16%
For compound 4 the middle estimate is 24 percentage points above the measured one; the range from low to high includes it.
By their numbers in this assay, from the lowest: compound 4; then compound 3; then compound 2. At a limit, above all of these: compound 1.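

Changing amino to benzylamino brought a number at least 64 percentage points lower from compound 1 to compound 4 (beyond the scatter) in this assay, a large fall in inhibition. The nitrogen of the amino group is therefore a second place, after the aromatic carbon changed in compound 3, where a group carrying a benzyl ring comes with lower inhibition, and none of the compounds with a listed step goes against this. Compound 1 stands at a limit, so the true size of the step stays open: the limit of > 80% in this assay, at which 1 of the 4 values shown sits.

The compounds shown leave open whether the fall needs the whole benzyl group, or whether a small methyl on the same nitrogen would lower inhibition as well. They also leave open what a longer chain such as phenylethyl, or an acetyl group, would do at that nitrogen.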